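This account rests on a few compounds, and the source may have more. Where it says the series, first, only, none or still open, it means among the compounds named here.

Working notes on the quinoline amide series. Compound 1 `Cc1ccc2nc(C(=O)Nc3c(F)cc(-c4cccc(F)c4)cc3F)c(C)c(O)c2c1` carries a hydroxy on its core and in a functional assay on A-375 cells (Homo sapiens) for antiproliferative activity, read by MTT assay, with a stated time of 24 h (a lower number here means a stronger inhibitor, a higher number a weaker inhibitor), compound 1 gives 90500 nM. Compound 3 `Cc1ccc2nc(C(=O)Nc3c(F)cc(-c4cccc(F)c4)cc3F)c(C)c(C(=O)O)c2c1` differs by carboxy in place of hydroxy on an aromatic carbon and compound 3 gives 26000 nM, so the change brings a 3.5-fold lower number from compound 1 to compound 3 (0.54 log units; beyond the scatter). Compound 2 `COc1ccc2nc(C(=O)Nc3ccc(-c4ccccc4)cc3)c(C)c(O)c2c1` gives 50600 nM; the difference between the core of compound 2 and the core of compound 1 is not broken down here, and the two values lie within the scatter of each other. Compound 4 `COc1ccc2nc(C(=O)Nc3ccc(-c4ccccc4)cc3)c(C)c(C(=O)O)c2c1` is compound 2 with carboxy in place of hydroxy on an aromatic carbon, the same change at the same place. Compound 4 is expected near 14500 nM, between 6000 nM and 40000 nM, an expected step of a 3.5-fold lower number from compound 2 to compound 4 (0.54 log units; beyond the scatter). Among the measured compounds shown here, the expectation is modest in confidence because a 3.5-fold lower number from compound 1 to compound 3 (0.54 log units; beyond the scatter) is the only example of this change available, seen once on a different core.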

Compound 4, half-maximal inhibitory concentration: > 100000 nM
Compound 4: only a limit was reported (the forecaster's own chance of this, stated with the estimate: 10%); at least 6.8-fold (0.83 log units) between middle value and limit.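

In this assay compound 4 gives > 100000 nM, which is a limit of the assay and not a number: the limit of > 100000 nM in this assay, at which 1 of the 4 values shown sits. Read from that floor, carboxy in place of hydroxy on an aromatic carbon gives an at least 1.9-fold higher number from compound 2 to compound 4 (0.29 log units; that floor lies within the scatter), and it does not carry over as a fixed step from the core of compound 1 to the core of compound 2: the same change on two cores in this assay, a 3.5-fold lower number (0.54 log units; beyond the scatter) from compound 1 to compound 3 and an at least 1.9-fold higher number (0.29 log units; that floor lies within the scatter) from compound 2 to compound 4, at least 6.8-fold (0.83 log units) apart, beyond the scatter of two such steps. This shows that the step depended on the core in these two pairs, but with one pair per core it gives no general rule and no actual size for the second step.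

Open, from the compounds shown here alone, is which difference between the two cores matters, the methyl or methoxy group or the fluorines on the aromatic rings of the amide part. Also open, going by these compounds, is whether an amine in place of the hydroxy would follow either step.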